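Adding a Cyclobutyl to the Primary Amide of Compound 3

The source may report more compounds than this note shows. Statements on the series, on what has been measured and on what is new or still open speak of the compounds shown alone.

Compound 1 `C=CC[C@@H]1C[C@@H](c2ccc(Cl)c(Cl)c2)[C@H](NC(=O)c2cc(-c3c(Cl)cnn3C)c(Cl)o2)CN1`: 12.4 nM
Compound 2 `COCC[C@@H]1C[C@@H](c2ccc(Cl)c(Cl)c2)[C@H](NC(=O)c2cc(-c3c(Cl)cnn3C)c(Cl)o2)CN1`: 7.01 nM
Compound 3 `Cn1ncc(Cl)c1-c1cc(C(=O)N[C@@H]2CN[C@H](CC(N)=O)C[C@H]2c2ccc(Cl)c(Cl)c2)oc1Cl`: 3.24 nM

In an assay for inhibition of RAC-alpha serine/threonine-protein kinase (Homo sapiens), read by HTRF, with a stated time of 1 h (on this read-out higher numbers stand for weaker inhibition and lower numbers for stronger inhibition), compound 3 gives the lowest number of the three, with a 2.2-fold lower number from compound 2 to compound 3 (0.34 log units; beyond the scatter) and a 3.8-fold lower number from compound 1 to compound 3 (0.58 log units; beyond the scatter) separating it from the others. Compound 4 `Cn1ncc(Cl)c1-c1cc(C(=O)N[C@@H]2CN[C@H](CC(=O)NC3CCC3)C[C@H]2c2ccc(Cl)c(Cl)c2)oc1Cl` differs from compound 3 by cyclobutyl in place of hydrogen on an amide-type nitrogen. The steps measured so far all alter the chain on the saturated ring carbon and leave the carbamoyl itself untouched, so none speaks directly to a substituent on its nitrogen. With no guide beyond that, compound 4 is expected to stay close to compound 3, with a step of a 1.5-fold higher number from compound 3 to compound 4 (0.19 log units; within the scatter) that may well fall within the scatter. The estimate for compound 4 is therefore 5 nM, ranging from 1.5 nM to 16 nM.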

Compound 4, half-maximal inhibitory concentration: 7.98 nM
For compound 4 the middle estimate is 1.6-fold (0.20 log units) below the measured one; measured number inside the range.
By their numbers in this assay, from the lowest: compound 3; then compounds 2, 4 and 1 (each within the scatter of the next).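

Unlike the earlier steps, which changed the chain, this one changes the carbamoyl nitrogen itself: in this assay, cyclobutyl in place of the amide hydrogen gives a 2.5-fold higher number from compound 3 to compound 4 (0.39 log units; beyond the scatter), a modest cost in inhibition. The comparisons with the other chains, a 1.1-fold higher number from compound 2 to compound 4 (0.06 log units; within the scatter) and a 1.6-fold lower number from compound 1 to compound 4 (0.19 log units; within the scatter), both lie within the scatter, so the edge compound 3 holds over compounds 1 and 2 does not carry over to compound 4. Nothing available explains this step. On these data alone, whether a methyl group or a cyclohexyl ring on that nitrogen would fare differently stays open, as does the effect of a carboxylic acid in place of the amide.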